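Swapping the pyrrolidinyl of compound 3 for an isopropylpiperazinyl

The compounds below may be only part of what the source reports. "The series", "measured", "known", "first", "only" and "open" are said of these compounds alone.

Measured compounds:
Compound 1 `FC(F)(F)c1ccc(Nc2ncnc3sc(Nc4c(Cl)cccc4Cl)nc23)cc1` gives 3 nM in a functional assay on HEK293 cells for antagonist activity at transient receptor potential cation channel subfamily V member 1 (Rattus norvegicus), read by calcium flux; a higher number here means a weaker inhibitor, a lower number a stronger inhibitor.
Compound 2 `CSc1ccccc1Nc1nc2c(Nc3ccc(C(F)(F)F)cc3)ncnc2s1` gives 26 nM in this assay.
Compound 3 `FC(F)(F)c1ccc(Nc2nc(N3CCCC3)nc3sc(Nc4c(Cl)cccc4Cl)nc23)cc1` gives 36 nM in this assay.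

Compound 3 carries the highest number of the three in this assay. Its nearest neighbour is compound 2, a gap that lies within the scatter, while compound 1 stands well apart: a 12-fold higher number from compound 1 to compound 3 (1.08 log units; beyond the scatter). Compound 4 `CC(C)N1CCN(c2nc(Nc3ccc(C(F)(F)F)cc3)c3nc(Nc4c(Cl)cccc4Cl)sc3n2)CC1` differs from compound 3 in one place: 4-isopropylpiperazin-1-yl in place of pyrrolidin-1-yl on an aromatic carbon. Among the compounds with values here, no measured pair shows one amine exchanged for another at this position; the only step that touches the site is the one from compound 1 to compound 3, where putting pyrrolidin-1-yl on that aromatic carbon raised the number by a large amount. The step from compound 3 to compound 4 is therefore expected to be small, most likely a modest further rise in this assay, a 1.7-fold higher number from compound 3 to compound 4 (0.22 log units; within the scatter). Compound 4 is estimated at 60 nM, within a range of 15 nM to 300 nM.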

Compound 4, half-maximal inhibitory concentration: 119 nM
Estimate against measurement, compound 4: 2.0-fold (0.30 log units) below, within the range that was stated.
By their numbers in this assay, from the lowest: compound 1; then compounds 2 and 3 (each within the scatter of the next); then compound 4.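

In this assay, the identity of the amine on this aromatic carbon matters, not only its presence: 4-isopropylpiperazin-1-yl in place of pyrrolidin-1-yl gives a 3.3-fold higher number from compound 3 to compound 4 (0.52 log units; beyond the scatter). Measured against hydrogen at the same place, the new group gives a 40-fold higher number from compound 1 to compound 4 (1.60 log units; beyond the scatter), so both amines shown here carry a higher number than hydrogen, and they differ from each other by more than the scatter. Nothing available explains this difference.

The compounds shown leave open whether the rise follows the isopropyl, the second ring nitrogen or the six-membered ring; morpholin-4-yl, unsubstituted piperazin-1-yl or dimethylamino on this carbon would help to separate these. On these data alone, it also remains open whether these amines shift the number to the same extent when 2-(methylsulfanyl)phenyl replaces 2,6-dichlorophenyl.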